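The source may hold more compounds than are shown below. What is called first, only, known or untested is meant among the compounds shown, and "the series" means these compounds.

Within the data shown here, compound 2 `Cc1cc(C)c(Oc2cc(Nc3ccc(C#N)cc3)ncc2C(=O)NCc2cn(CC(N)=O)nn2)c(C)c1` gives the lower of the two numbers measured so far in an ADME assay on MT4 cells (Homo sapiens) for cytotoxicity, read by MTT assay, with a stated time of 5 days (a higher number here means that more compound is tolerated, a lower number that less compound is tolerated), 24000 nM. Compound 1 `Cc1cccc(Cn2cc(CNC(=O)c3cnc(Nc4ccc(C#N)cc4)cc3Oc3c(C)cc(C)cc3C)nn2)c1` gives 114000 nM in this assay. Among the measured compounds shown here, the only measured step bearing on the change, a 4.8-fold lower number from compound 1 to compound 2 (0.68 log units; beyond the scatter), replaced an aromatic ring at this position with carbamoyl. Compound 3 `Cc1cc(C)c(Oc2cc(Nc3ccc(C#N)cc3)ncc2C(=O)NCc2cn(Cc3ccc(F)cc3)nn2)c(C)c1` goes the other way: 4-fluorophenyl in place of carbamoyl on a saturated chain carbon bound to an aromatic nitrogen. An aromatic ring returns at the same position, as in compound 1, so a higher number is expected, and the step from compound 2 to compound 3 is estimated as a 3.8-fold higher number from compound 2 to compound 3 (0.57 log units; beyond the scatter). Compound 3 is expected at 90000 nM, within 35000 nM to 200000 nM.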

Compound 3, half-maximal cytotoxic concentration: >= 153000 nM
Compound 3 gave a limit, no number (the forecaster's own chance of this, stated with the estimate: 25%); middle value at least 1.7-fold (0.23 log units) away from the limit.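

Compound 3 gives a limit of this assay, not a number: the limit of >= 153000 nM in this assay, at which 1 of the 3 values shown sits. The lower number with carbamoyl on this saturated chain carbon now holds against a second aromatic ring, with an at least 6.3-fold higher number from compound 2 to compound 3 (0.80 log units; beyond the scatter). Between the two aromatic groups, the change to 4-fluorophenyl in place of 3-methylphenyl gives an at least 1.3-fold higher number from compound 1 to compound 3 (0.12 log units; that floor lies within the scatter), and that floor does not separate them.

Going by these compounds, how far the value of compound 3 lies past its limit remains open. So does whether an amine or a carboxylic acid at this place would give a number like that of carbamoyl.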